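Ketone chain and aryl ether end in an allosteric series

A few compounds are considered here, and "the series" means these few. Any claim that something is new, unique, unknown or untested is made for them only; others in the source may bear on it.

Measured so far:
compound 1 `CCC(=O)c1ccc(OCCCCOc2ccc(F)c(C(=O)O)c2)c(C)c1O`, 18.4%
compound 2 `Cc1c(OCCCCOc2ccc(F)c(C(=O)O)c2)ccc(C(=O)CC2CCCC2)c1O`, 98.4%
compound 3 `CCCC(=O)c1ccc(OCCCCOc2ccc(F)c(C(=O)O)c2)c(C)c1O`, 56.9%

In an assay on HEK293 cells for positive allosteric modulation of metabotropic glutamate receptor 3 (Rattus norvegicus), read by thallium flux, with a stated time of 2.5 min (on this read-out lower numbers stand for smaller maximal responses and higher numbers for larger maximal responses), compound 2 stands highest of the three: a number 41.5 percentage points lower from compound 2 to compound 3 (beyond the scatter) and a number 80 percentage points higher from compound 1 to compound 2 (beyond the scatter), both beyond the scatter. Every measured step changes only the carbon chain on the carbonyl. Compound 4 `COC(=O)c1ccc(OCCCCOc2ccc(C(=O)CC3CCCC3)c(O)c2C)cc1` differs from compound 2 at the other end: 4-(methoxycarbonyl)phenyl in place of 3-carboxy-4-fluorophenyl on an oxygen on a saturated carbon. Going by the values given here, no measured step touches this part of the molecule, so nothing here shows how this assay responds to it; the acid donor leaves and an ester enters, and the ketone chain of compound 2 is kept. With the ketone chain retained, compound 4 is expected to keep most of the response, estimated at 75% (range 30% to 105%), a step of a number 23.4 percentage points lower from compound 2 to compound 4 (beyond the scatter), with wide uncertainty.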

Compound 4, largest response reached (reported as percent of maximum), in percent of the reference or control that the assay uses: 22%
For compound 4 the middle estimate is 53 percentage points above the measured one; the measured number lies below the stated range.
By their numbers in this assay, from the lowest: compounds 1 and 4 (each within the scatter of the next); then compound 3; then compound 2.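

In this assay, going by these compounds alone, the aryl ether end, untouched by the earlier steps, also governs the response, with a number 76.4 percentage points lower from compound 2 to compound 4 (beyond the scatter) on 4-(methoxycarbonyl)phenyl entering in place of 3-carboxy-4-fluorophenyl. The cyclopentyl ketone chain therefore does not hold the response on its own. No evidence bearing on the cause of this step is at hand.

Still open, on these data alone, is which part of the exchange carries the step: the loss of the carboxylic acid, the loss of the fluorine, or the rearranged ring substitution. A 4-carboxyphenyl end or a primary amide in place of the acid would help separate these.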